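A few compounds are considered here, and "the series" means these few. Any claim that something is new, unique, unknown or untested is made for them only; others in the source may bear on it.

Compound 1 `CCCOC(=O)c1c(C)coc1-c1ccc2c(CC)cccc2c1OC` carries a propoxycarbonyl group on the five-membered ring of the shared core. In a functional assay on ZR-75-1 cells (Homo sapiens) for cytotoxicity, read by MTT assay, with a stated time of 72 h (a higher number here means that more compound is needed for the effect, a lower number that less compound is needed), compound 1 gives only a limit, > 10 ug/mL, and so its true value is not known (the limit of > 10 ug/mL in this assay, at which 1 of the 2 values shown sits). A second measured compound, compound 2 `CCOc1c(-c2occ(C)c2CO)ccc2c(CC)cccc12`, differs from compound 1 in more than one place and is therefore not a single step; in this assay compound 2 gives 1.4 ug/mL, a number rather than a limit.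

The unmeasured compound 3 `CCOCc1c(C)coc1-c1ccc2c(CC)cccc2c1OC` is compound 1 with ethoxymethyl in place of propoxycarbonyl on an aromatic carbon. Among the measured compounds shown here, no measured pair shows this change on its own, so the expectation for compound 3 rests on the two values shown: the limit of compound 1 and the number of compound 2, which sits well inside the measurable range. Compound 3 is expected to move away from the limit toward lower concentrations, and the estimated step from compound 1 to compound 3 is an at least 2.0-fold lower number from compound 1 to compound 3 (0.30 log units; that floor lies within the scatter). For compound 3 the estimated value in this assay is 5 ug/mL, with a likely range from 1.5 ug/mL to 15 ug/mL.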

Compound 3, concentration for half-maximal effect: 9.1 ug/mL
For compound 3 the middle estimate is 1.8-fold (0.26 log units) below the measured one, within the range that was stated.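

With ethoxymethyl in place of propoxycarbonyl on an aromatic carbon of the five-membered aromatic ring, the shared core now has a number at this position in this assay, where compound 3 gives 9.1 ug/mL. In this assay compound 1 gives > 10 ug/mL, which is a limit and not a number. The change can therefore be read only as a floor, an at least 1.0-fold lower number from compound 1 to compound 3 (0.04 log units; that floor lies within the scatter), and the pair does not establish a change beyond the scatter, because the true value of compound 1 stays unknown at the limit: the limit of > 10 ug/mL in this assay, at which 1 of the 3 values shown sits.

Compound 2 differs from compound 3 in more than one place, so its value cannot be set against this change on its own. The compounds shown leave open how far the true step runs and whether a carboxylic acid, an amine or a longer ether chain on this ring carbon would give a number in this assay that stands clear of compound 3 by more than the scatter.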